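Aryl swap on compound 2: notes before measurement

The source may report more compounds than this note shows. Statements on the series, on what has been measured and on what is new or still open speak of the compounds shown alone.

Measured so far in a functional assay on MIA PaCa-2 cells (Homo sapiens) for inhibition, read by MTT assay, with a stated time of 72 h, tested at 50 uM; on this read-out higher numbers stand for more inhibition of growth at the one concentration tested and lower numbers for less inhibition of growth:
compound 1 `C=CCc1cc(O)c(O)c(CN2CCC(CO)CC2)c1` gives 38.6%
compound 2 `C=CCc1ccc(OCc2cn(-c3ccccc3Cl)nn2)c(O)c1` gives 57.7%
compound 3 `C=CCc1cc(O)c(O)c(CN2CCC(CCO)CC2)c1` gives 71.8%

Compound 2 stands second highest of the three numbers. Its nearest neighbour is compound 3, higher by a gap beyond the scatter; the furthest is compound 1, lower by a gap beyond the scatter. Compound 4 `C=CCc1ccc(OCc2cn(-c3ccc(Br)cc3)nn2)c(O)c1` has not yet been measured in this assay. It differs from compound 2 in one place: 4-bromophenyl in place of 2-chlorophenyl on an aromatic nitrogen.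

Among the measured compounds shown here, the only measured step, a number 33.2 percentage points higher from compound 1 to compound 3 (beyond the scatter), concerns the hydroxy-bearing chain on the saturated ring shared by compound 1 and compound 3. It does not touch the aromatic nitrogen where the change from compound 2 to compound 4 sits, and the core of compound 2 is a different one, so it gives no guide here. For the measured compounds named here, no pair among the measured compounds shows what exchanging the group on the aromatic nitrogen does. With nothing to lean on, the expectation for compound 4 is a step not beyond the scatter, in either direction, with a wide range around it. The estimate for compound 4 is therefore 58%, within 40% to 76%. This amounts to an expected step of a number 0.3 percentage points higher from compound 2 to compound 4 (within the scatter).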

Compound 4, percent growth inhibition at one concentration: 47.3%
For compound 4 the middle estimate is 10.7 percentage points above the measured one; the range from low to high includes it.
By their numbers in this assay, from the lowest: compounds 1 and 4 (each within the scatter of the next); then compound 2; then compound 3.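

In this assay, among the compounds shown here, the group on the aromatic nitrogen of the five-membered aromatic ring with 3 nitrogen is the first place on the core of compound 2 where an exchange can be read: 4-bromophenyl in place of 2-chlorophenyl gives a number 10.4 percentage points lower from compound 2 to compound 4 (beyond the scatter) on this read-out. The two groups match in heavy-atom count, with 7 each, and both have one six-membered aromatic ring of carbon only, no hydrogen-bond donors or acceptors, and no net charge, so the read-out at this position can shift even when these counts stay the same. No measurement available here accounts for the step.

The exchange alters both the halogen and its place on the phenyl ring, and the compounds shown do not separate these two changes. From the compounds shown here alone, how a plain phenyl, a benzyl or a 4-methoxyphenyl group on the same nitrogen would read stays open, as does whether any group at this position could reach the level of compound 3 at 71.8% on its different core.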